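Working notes: an acetyl group on compound 1

The source may hold more compounds than are shown below. What is called first, only, known or untested is meant among the compounds shown, and "the series" means these compounds.

Within the data shown here, in a functional assay for inhibition, with Homo sapiens as the target (on this read-out higher numbers stand for weaker inhibition and lower numbers for stronger inhibition), compound 1 `Oc1cc2c(cc1CNc1ccccc1)OCC2` gives 490 nM, the lowest of the two numbers measured so far. Compound 2 `OCc1ccccc1NCc1cc2c(cc1O)CCO2` gives 11000 nM.

The next compound to read is compound 3 `CC(=O)c1ccc(NCc2cc3c(cc2O)CCO3)cc1`. Its change from the core of compound 1 is acetyl in place of hydrogen on an aromatic carbon, para to a large group (acetyl in place of hydrogen on an aromatic carbon).

Among the measured compounds shown here, only one measured step bears on this change: a 22-fold higher number from compound 1 to compound 2 (1.35 log units; beyond the scatter). That step is large and beyond the scatter, and it belongs to hydroxymethyl in place of hydrogen on an aromatic carbon. For the measured compounds named here, it shows that one added group can raise the number strongly in this pair, but no measured compound carries acetyl, so its size cannot simply be carried over.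

A smaller step towards a higher number is therefore expected in this assay, and a result within the scatter is not ruled out. The estimated step is a 2.7-fold higher number from compound 1 to compound 3 (0.42 log units; beyond the scatter). Compound 3 is expected at 1300 nM, with an estimated range of 350 nM to 6000 nM.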

Compound 3, half-maximal inhibitory concentration in the Homo sapiens assay: 1200 nM
Compound 3: middle estimate off by 1.1-fold (0.03 log units), on the high side; low and high end bracket the measured number.
By their numbers in the Homo sapiens assay, from the lowest: compound 1; then compound 3; then compound 2.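

Working notes, after compound 3: in the Homo sapiens assay, acetyl in place of hydrogen on an aromatic carbon, para to a large group, gives a 2.4-fold higher number from compound 1 to compound 3 (0.39 log units; beyond the scatter) and so counts as a modest step, while hydroxymethyl in place of hydrogen on an aromatic carbon gives the large 22-fold higher number from compound 1 to compound 2 (1.35 log units; beyond the scatter) in the same assay. Among these compounds, the series therefore tolerates this added group with a much smaller loss of inhibition than the only earlier step suggested, although the number still rises beyond the scatter. In a physicochemical assay for lipophilicity (on this read-out higher numbers stand for higher lipophilicity and lower numbers for lower lipophilicity), the same change gives no change at the digits printed from compound 1 to compound 3 (within the scatter) and leaves compound 1 at 2.9 and compound 3 at 2.9 in step with each other, and no supporting data are available to explain the shift in inhibition.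

Going by these compounds, whether this step belongs to acetyl in particular or to any group at this place stays open, and an amine or a carboxylic acid on the same aromatic carbon would help to separate the two readings. Also open in the Homo sapiens assay is whether any group here can bring the number under that of compound 1, as both added groups shown raise it.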